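Fluoropyridyl for methoxyphenyl on a pyrrolidinone-based lipase inhibitor

The compounds below may be only part of what the source reports. "The series", "measured", "known", "first", "only" and "open" are said of these compounds alone.

Of the compounds shown here, three sharing one core have been measured in an assay on isolated protein for inhibition of Monoglyceride lipase (Mus musculus), with a stated time of 30 min; on this read-out lower numbers stand for stronger inhibition and higher numbers for weaker inhibition. Compound 1 `COc1ccccc1-c1ccc(N2CC(N3CCN(C(=O)c4ccco4)CC3)CC2=O)cc1` gives 30 nM, and compound 2 `O=C(c1ccco1)N1CCN(C2CC(=O)N(c3ccc(-c4ccccc4F)cc3)C2)CC1` gives 37 nM; the step of a 1.2-fold higher number from compound 1 to compound 2 (0.09 log units; within the scatter) lies within the scatter. Compound 3 `COc1ccccc1-c1cccc(N2CC(N3CCN(c4ncccn4)CC3)CC2=O)c1` gives 85 nM, the highest number of the three, beyond the scatter from both others. Compound 4 `O=C1CC(N2CCN(c3ncccn3)CC2)CN1c1cccc(-c2cccnc2F)c1` differs from compound 3 by 2-fluoropyridin-3-yl in place of 2-methoxyphenyl on an aromatic carbon. Among the measured compounds shown here, only the step from compound 1 to compound 2 bears on this change, and it was within the scatter; nothing measured speaks to the ring nitrogen that enters. Compound 4 is therefore expected to show no step beyond the scatter in this assay, no change at the digits printed from compound 3 to compound 4 (within the scatter). Compound 4 is estimated at 85 nM, within 35 nM to 210 nM.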

Compound 4, half-maximal inhibitory concentration: 305 nM
Compound 4: the middle estimate sits 3.6-fold (0.55 log units) below what was measured; measured number above the stated range.
By their numbers in this assay, from the lowest: compounds 1 and 2 (each within the scatter of the next); then compound 3; then compound 4.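

On the aromatic carbon meta to a large group, this change is not neutral in this assay: the step of a 3.6-fold higher number from compound 3 to compound 4 (0.55 log units; beyond the scatter) lies beyond the scatter, whereas the fluoro-for-methoxy step a 1.2-fold higher number from compound 1 to compound 2 (0.09 log units; within the scatter) stayed within it. The earlier step therefore did not carry over to 2-fluoropyridin-3-yl in place of 2-methoxyphenyl. Nothing available gives a cause for this difference. The compounds shown leave open whether the ring nitrogen or the fluorine governs the step. A 2-methoxypyridin-3-yl or a plain pyridin-3-yl at this place would separate the two.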